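Hydroxymethyl to formyl on a three-carbon chain

The source may hold more compounds than are shown below. What is called first, only, known or untested is meant among the compounds shown, and "the series" means these compounds.

Measured so far in an assay on 32D cells for inhibition of interleukin-15 (Mus musculus), read by resazurin assay, with stated times of 30 min and 2.5 days, in the presence of a further agent that is not named here; on this read-out higher numbers stand for weaker inhibition and lower numbers for stronger inhibition:
compound 1 `Cn1nc(Cc2nnc(SCC(=O)Nc3ccc(Cl)cc3Cl)n2CCC=O)c2ccccc2c1=O` gives 6000 nM;
compound 2 `Cn1nc(Cc2nnc(SCC(=O)Nc3ccc(Cl)cc3Cl)n2CCCO)c2ccccc2c1=O` gives only a limit, > 30000 nM;
compound 3 `Cn1c(Cc2nn(CCCO)c(=O)c3ccccc23)nnc1SCCCCCCCC(=O)Nc1ccc(Cl)cc1Cl` gives only a limit, > 30000 nM.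

Compounds 1 and 2 share one core and differ only at the end of a short chain. The change is formyl in place of hydroxymethyl on a saturated chain carbon, two bonds along the chain from an aromatic nitrogen. This step, an at least 5.0-fold lower number from compound 2 to compound 1 (0.69 log units; beyond the scatter), is beyond the scatter of this assay, though since compound 2 sits at a limit its true size is not known.

Compound 3 carries the same chain ending in hydroxymethyl, but on a different core, and the difference between the two cores is not broken down here. Compound 4 `Cn1c(Cc2nn(CCC=O)c(=O)c3ccccc23)nnc1SCCCCCCCC(=O)Nc1ccc(Cl)cc1Cl` is the formyl partner of compound 3, not yet measured in this assay. The change from compound 3 to compound 4 is formyl in place of hydroxymethyl on a saturated chain carbon, two bonds along the chain from an aromatic nitrogen; the place of the change is the same as from compound 2 to compound 1, so it is the same change on a different core.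

The expectation for compound 4 rests on a single measured pair, and it is wide because compound 3 sits at the limit of > 30000 nM in this assay, at which 2 of the 3 values shown sit, so the starting point itself is only a limit. The step from compound 3 to compound 4 is expected to be an at least 2.0-fold lower number from compound 3 to compound 4 (0.30 log units; that floor lies within the scatter). In this assay compound 4 is estimated at 15000 nM, between 4000 nM and 60000 nM, with a real chance that only a limit is reported again.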

Compound 4, half-maximal inhibitory concentration: 8900 nM
Beside the measured number, compound 4's estimate is 1.7-fold (0.23 log units) above it, within the range that was stated.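

In this assay, formyl in place of hydroxymethyl on the three-carbon chain gives an at least 3.3-fold lower number from compound 3 to compound 4 (0.52 log units; beyond the scatter). Set beside the earlier pair, the change lowers the number on both cores shown, so its direction carries over from one core to the other in these two pairs: the same change on two cores in this assay, an at least 5.0-fold lower number (0.69 log units; beyond the scatter) from compound 2 to compound 1 and an at least 3.3-fold lower number (0.52 log units; beyond the scatter) from compound 3 to compound 4; the limit leaves it open whether they differ. This does not give the true size of the step on either core, and two cores cannot show that the change would work on a third, as both starting compounds stand only at a limit: the limit of > 30000 nM in this assay, at which 2 of the 4 values shown sit.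

The compounds shown leave open what other chain ends would do on these cores, for example an amine or a carboxylic acid in place of the formyl, and whether a longer chain carrying the formyl would keep the lower number. They also leave open how the two cores compare with each other, for compound 1 and compound 4 differ in more than one place, so the effect of any single difference between them cannot be read from their values.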